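The source may report more compounds than this note shows. Statements on the series, on what has been measured and on what is new or still open speak of the compounds shown alone.

Measured compounds:
- compound 1, `CCC(C(=O)N1CCN(c2cccc(Cl)c2)CC1)N1C(=O)CCC1=O`: 50%
- compound 2, `CCC(C(=O)N1CCN(c2ccccc2)CC1)N1C(=O)CCC1=O`: 75%
- compound 3, `CCC(C(=O)N1CCN(c2cccc(C(F)(F)F)c2)CC1)N1C(=O)CCC1=O`: 50%

In a functional assay on the whole organism (strain Swiss) with Mus musculus as the target, in the maximal electroshock model, with a stated time of 0.5 h, at a dose of 300 mg/kg by the intraperitoneal route (on this read-out lower numbers stand for a weaker effect and higher numbers for a stronger effect at the one dose given), compound 2 gives 75%, the highest of the three numbers. Compound 1 gives 50%, a step of a number 25 percentage points higher from compound 1 to compound 2 (beyond the scatter). Compound 3 gives 50%, a step of a number 25 percentage points lower from compound 2 to compound 3 (beyond the scatter). Between compound 1 and compound 3 the step is no change at the digits printed from compound 1 to compound 3 (within the scatter).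

Compound 4, `CC(C(=O)N1CCN(c2ccccc2)CC1)N1C(=O)CCC1=O`, has not been measured. It differs from compound 2 in one place: hydrogen in place of methyl on a saturated chain carbon, two bonds along the chain from an amide-type nitrogen in a ring and a carbonyl carbon. All three measured steps change a group on the aromatic ring, so none of them bears on this shortening of the chain. The data give no guide to the size or direction of the step. With compound 2 as the only anchor, compound 4 is expected to stay near it, as a step of a number 15 percentage points lower from compound 2 to compound 4 (beyond the scatter) in this assay, a guess with wide bounds. Compound 4 is therefore estimated at 60%, between 25% and 100%.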

Compound 4, a percentage reported as activity, at one dose (the size of the read-out at that dose, not a potency): 50%
Compound 4: middle estimate off by 10 percentage points, on the high side; measured number inside the range.
By their numbers in this assay, from the lowest: compounds 1, 3 and 4 (each within the scatter of the next); then compound 2.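

The earlier steps shown here all changed a group on the aromatic ring, while this one shows that the read-out in this assay also responds to a change on a saturated chain carbon, two bonds along the chain from an amide-type nitrogen in a ring and a carbonyl carbon. Cutting ethyl to methyl there, with the rest of the structure kept, gives a number 25 percentage points lower from compound 2 to compound 4 (beyond the scatter), so at the one dose given, the ethyl compound has the higher number of this pair. No measurement here explains this step.

From the compounds shown here alone, whether a longer chain, such as propyl, or a branched one, such as isopropyl, would raise or lower the number remains open. Also open, going by these compounds, is whether the same shortening would give a similar step with chloro or trifluoromethyl on the aromatic ring, as this position rests on a single pair of compounds.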